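The source may hold more compounds than are shown below. What is called first, only, known or untested is meant among the compounds shown, and "the series" means these compounds.

Working notes on the series. The shared core of compound 1 `CC[C@H]1OC(=O)[C@H](C)C(=O)[C@H](C)[C@@H](O[C@@H]2O[C@H](C)C[C@H](N(C)C)[C@H]2O)[C@](C)(O)C[C@@H](C)C(=O)[C@H](C)[C@H]2N(C3CN(Cc4ccnc5cccnc45)C3)C(=O)O[C@]12C` is kept throughout; the compounds differ only in the group on a saturated chain carbon bound to an amine nitrogen in a ring. In an ADME assay on microsomes from liver (Homo sapiens) for metabolic stability, tested at 1 uM (a lower number here means that the liver removes a smaller share, a higher number that the liver removes a larger share of the compound in one pass), compound 1 gives 0.7. Compound 2 `CC[C@H]1OC(=O)[C@H](C)C(=O)[C@H](C)[C@@H](O[C@@H]2O[C@H](C)C[C@H](N(C)C)[C@H]2O)[C@](C)(O)C[C@@H](C)C(=O)[C@H](C)[C@H]2N(C3CN(Cc4c(OC)cnc5ccccc45)C3)C(=O)O[C@]12C` gives 0.6 in this assay, the lowest of the three numbers, though a number 0.10 lower from compound 1 to compound 2 (within the scatter) lies within the scatter. Compound 3 `CC[C@H]1OC(=O)[C@H](C)C(=O)[C@H](C)[C@@H](O[C@@H]2O[C@H](C)C[C@H](N(C)C)[C@H]2O)[C@](C)(O)C[C@@H](C)C(=O)[C@H](C)[C@H]2N(C3CN(Cc4c(OC)cnc5ncccc45)C3)C(=O)O[C@]12C` gives 0.8 in this assay, with a number 0.10 higher from compound 1 to compound 3 (within the scatter) within the scatter and a number 0.20 higher from compound 2 to compound 3 (beyond the scatter) beyond it.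

Compound 4 `CC[C@H]1OC(=O)[C@H](C)C(=O)[C@H](C)[C@@H](O[C@@H]2O[C@H](C)C[C@H](N(C)C)[C@H]2O)[C@](C)(O)C[C@@H](C)C(=O)[C@H](C)[C@H]2N(C3CN(Cc4c(O)cnc5ncccc45)C3)C(=O)O[C@]12C` is not yet measured. Its change from compound 2: a group of 11 heavy atoms (8 carbon, 2 nitrogen, 1 oxygen; 2 six-membered aromatic rings with 1 hetero atom each) in place of a group of 12 heavy atoms (10 carbon, 1 nitrogen, 1 oxygen; one six-membered aromatic ring of carbon only, one six-membered aromatic ring with 1 hetero atom), on a saturated chain carbon bound to an amine nitrogen in a ring. The step that bears on this is a number 0.20 higher from compound 2 to compound 3 (beyond the scatter), where the two six-membered aromatic rings with one hetero atom each also replace the 3-methoxyquinolin-4-yl group. For the measured compounds named here, no measured step covers the exchange of the methoxy for the hydroxy, so that part carries no expectation of its own. A rise of about the size seen from compound 2 to compound 3 is therefore expected, as a number 0.20 higher from compound 2 to compound 4 (beyond the scatter). For compound 4 the estimate in this assay is 0.8, with a range from 0.6 to 0.9.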

Compound 4, hepatic extraction ratio: < 0.3
Compound 4: only a limit was reported; the forecaster's own chance of this, stated with the estimate: 5%; at least 0.50 between middle value and limit.
By their numbers in this assay, from the lowest: compounds 2, 1 and 3 (each within the scatter of the next, the first and the last beyond it). At a limit, below all of these: compound 4.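

In this assay compound 4 stands at a limit and not at a number: the limit of < 0.3 in this assay, at which 1 of the 4 values shown sits. The exchange of hydrogen for methyl on an oxygen on an aromatic ring gives a number at least 0.50 lower from compound 3 to compound 4 (beyond the scatter), so a change of this small size at this position moves the read-out further than any step among compound 1, compound 2 and compound 3 did. The other two steps, a number at least 0.30 lower from compound 2 to compound 4 (beyond the scatter) and a number at least 0.40 lower from compound 1 to compound 4 (beyond the scatter), are also beyond the scatter, which sets compound 4 apart from all three earlier compounds.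

Going by these compounds, how far under its limit compound 4 lies stays open, and so does whether the same exchange would act alike on the quinoline of compound 2. Also open, on these data alone, is whether an amine or a carboxylic acid in place of the hydroxy would follow the hydroxy or the methoxy.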